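Adding a second acetoxy group: compound 2 to compound 4

The source may report more compounds than this note shows. Statements on the series, on what has been measured and on what is new or still open speak of the compounds shown alone.

Of the compounds shown here, three on a shared core have been measured in a functional assay on a cell-free system (plasma, Homo sapiens) for inhibition; on this read-out lower numbers stand for stronger inhibition and higher numbers for weaker inhibition. Compound 1 `COc1ccc(/C=C/C(=O)Nc2nccs2)cc1` gives 73700 nM, compound 3 `COc1ccc(/C=C/C(=O)Nc2nccs2)cc1OC` gives 54500 nM, and compound 2 `CC(=O)Oc1cccc(/C=C/C(=O)Nc2nccs2)c1` gives 35500 nM. Compound 2 stands below compound 1 by a margin beyond the scatter, while it sits within the scatter of compound 3. For the measured compounds named here, the only single-point step among the measured compounds, a 1.4-fold lower number from compound 1 to compound 3 (0.13 log units; within the scatter), puts a methoxy in place of hydrogen on an aromatic carbon and stays within the scatter.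

Compound 4 `CC(=O)Oc1ccc(/C=C/C(=O)Nc2nccs2)cc1OC(C)=O` differs from compound 2 in one place: acetoxy in place of hydrogen on an aromatic carbon. Going by the values given here, no measured step adds an acetoxy, so the one oxygen-substituent addition recorded so far, small as it was, is the nearest guide. Compound 4 is therefore expected to land close to compound 2, with a 1.2-fold lower number from compound 2 to compound 4 (0.07 log units; within the scatter) not beyond the scatter. In this assay compound 4 is estimated at 30000 nM, with a range from 12000 nM to 75000 nM.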

Compound 4, half-maximal inhibitory concentration: 75600 nM
The estimate for compound 4 lay 2.5-fold (0.40 log units) below the measured number; measured number above the stated range.
By their numbers in this assay, from the lowest: compounds 2, 3, 1 and 4 (each within the scatter of the next, the first and the last beyond it).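

In this assay, for the compounds shown here, acetoxy in place of hydrogen on an aromatic carbon, ortho to an acetoxy group and para to a large group, gives a 2.1-fold higher number from compound 2 to compound 4 (0.33 log units; beyond the scatter) and so moves toward weaker inhibition; this is the first single-place change to lie beyond the scatter. The earlier step, a 1.4-fold lower number from compound 1 to compound 3 (0.13 log units; within the scatter) with methoxy entering, stayed within it, but the two steps start from different compounds, so the contrast cannot be assigned to the entering group alone. No measurement at hand bears on the origin of this shift.

The compounds shown leave open whether the shift belongs to acetoxy specifically or would also follow from another group in the same place, such as a hydroxy group or an amine. They also leave open how the same acetoxy addition behaves on a different parent compound.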